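The source may report more compounds than this note shows. Statements on the series, on what has been measured and on what is new or still open speak of the compounds shown alone.

Measured so far:
compound 1 `NCc1ccc(C(=O)Nc2ccncc2F)cc1-c1cccc(C(=O)O)c1` — 55 nM
compound 2 `CC(C)OCCOC(=O)c1cccc(-c2cc(C(=O)Nc3ccncc3F)ccc2CN)c1` — 37 nM
compound 3 `CCOC(=O)c1cccc(-c2cc(C(=O)Nc3ccncc3)ccc2CN)c1` — < 1 nM, a limit of the assay rather than a number

In an assay on isolated protein for inhibition of Rho-associated protein kinase 2 (Homo sapiens), read by radiometric assay (a higher number here means a weaker inhibitor, a lower number a stronger inhibitor), compound 1 gives 55 nM, one of only two plain numbers shown, and compound 2 gives 37 nM, a value within the scatter of it. For compound 3 the result < 1 nM is a limit of the assay, not a number. Compound 4 `NCc1ccc(C(=O)Nc2ccncc2F)cc1-c1cccc(C(=O)OCC2CCCO2)c1` differs from compound 1 as follows: (oxolan-2-yl)methyl in place of hydrogen on an oxygen next to a carbonyl group. For the measured compounds named here, the one measured step that bears on this is a 1.5-fold lower number from compound 1 to compound 2 (0.17 log units; within the scatter), where 2-isopropoxyethyl took the place of the same hydrogen. A step of similar, small size is therefore expected, a 1.6-fold lower number from compound 1 to compound 4 (0.20 log units; within the scatter), staying within the scatter. Compound 4 is estimated at 35 nM, with a likely range from 15 nM to 90 nM.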

Compound 4, half-maximal inhibitory concentration: 2.5 nM
The estimate for compound 4 lay 14-fold (1.15 log units) above the measured number, and the stated range ends above it.
By their numbers in this assay, from the lowest: compound 4; then compounds 2 and 1 (each within the scatter of the next). At a limit, below all of these: compound 3.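

Putting a group on this oxygen is not a neutral change, as two steps show. The 2-isopropoxyethyl group gave a 1.5-fold lower number from compound 1 to compound 2 (0.17 log units; within the scatter), whereas (oxolan-2-yl)methyl gave a 22-fold lower number from compound 1 to compound 4 (1.34 log units; beyond the scatter). The two esters themselves also differ clearly, with a 15-fold lower number from compound 2 to compound 4 (1.17 log units; beyond the scatter), so the outcome depends on which group is attached, and nothing measured here explains why.

As far as these compounds go, it remains open whether the oxolane ring itself matters. An (oxan-2-yl)methyl ester, or an amide carrying the same (oxolan-2-yl)methyl group, on the core of compound 1 would help to test this.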